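The compounds below may be only part of what the source reports. "The series", "measured", "known", "first", "only" and "open" are said of these compounds alone.

Measured compounds in a functional assay on Caco-2 cells (Homo sapiens) for antiproliferative activity, read by MTT assay, with a stated time of 48 h; on this read-out higher numbers stand for weaker inhibition and lower numbers for stronger inhibition:
- compound 1 `CCn1c(C(=O)NCCN(C)C)ccc1C(CC)(CC)c1ccc(OCCC(O)(CC)CC)c(C)c1`: 1140 nM
- compound 2 `CCn1c(C(=O)Nc2ccc(OC(F)(F)F)cc2)ccc1C(CC)(CC)c1ccc(OCCC(O)(CC)CC)c(C)c1`: compound 2 reaches only the limit > 50000 nM
- compound 3 `CCn1c(C(=O)Nc2cccc(C(F)(F)F)c2)ccc1C(CC)(CC)c1ccc(OCCC(O)(CC)CC)c(C)c1`: compound 3 reaches only the limit > 50000 nM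

Among the measured compounds shown here, compound 1 gives the only number in this set; the other two values are limits. Compound 4 `CCOc1ccc(NC(=O)c2ccc(C(CC)(CC)c3ccc(OCCC(O)(CC)CC)c(C)c3)n2CC)cc1` differs from compound 1 by 4-ethoxyphenyl in place of 2-(dimethylamino)ethyl on an amide-type nitrogen. The two measured steps that bear on this replace the same 2-(dimethylamino)ethyl by an aryl group: an at least 43-fold higher number from compound 1 to compound 2 (1.64 log units; beyond the scatter) and an at least 43-fold higher number from compound 1 to compound 3 (1.64 log units; beyond the scatter). Both end at the limit of > 50000 nM in this assay, at which 2 of the 3 values shown sit. A third aryl amide is therefore expected to behave alike, with a large upward step in this assay. Compound 4 is expected to give about 50000 nM, in the range 10000 nM to 200000 nM. This estimate means a 44-fold higher number from compound 1 to compound 4 (1.64 log units; beyond the scatter), most likely reported as a limit.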

Compound 4, half-maximal inhibitory concentration: > 50000 nM
Compound 4 was reported as a limit; the forecaster's own chance of this, stated with the estimate: 70%; the middle value lies on the limit itself.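

In this assay, 4-ethoxyphenyl on the amide-type nitrogen gives an at least 43-fold higher number from compound 1 to compound 4 (1.64 log units; beyond the scatter), so the loss is not confined to aryl groups carrying fluorine. All three aryl amides shown now share one reported limit, not a number: the limit of > 50000 nM in this assay, at which 3 of the 4 values shown sit. The steps among compound 2, compound 3 and compound 4 cannot be read, as both ends of each are limits.

Open, on these data alone, is which part of 2-(dimethylamino)ethyl matters for the number of compound 1. A 3-(dimethylamino)propyl chain, a 2-hydroxyethyl group or a phenyl ring bearing an amine on the same nitrogen would address this.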